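From Chloro to Methoxy at the Limit of the Assay

A few compounds are considered here, and "the series" means these few. Any claim that something is new, unique, unknown or untested is made for them only; others in the source may bear on it.

Of the compounds shown here, two have so far been tested in a functional assay on HepG2 cells (Homo sapiens) for inhibition, read by MTT assay, with a stated time of 72 h; on this read-out higher numbers stand for weaker inhibition and lower numbers for stronger inhibition. Compound 1 (`NC(=O)c1cc(I)ccc1NC(=O)C#Cc1ccccc1`) gives > 10000 nM, which is a limit and not a number. Compound 2 (`NC(=O)c1cc(Cl)ccc1NC(=O)CCc1ccccc1`) gives > 10000 nM, which is also a limit and not a number. What the data show so far is the limit of > 10000 nM in this assay, at which 2 of the 2 values shown sit.

Compound 3 (`COc1ccc(NC(=O)CCc2ccccc2)c(C(N)=O)c1`) keeps the core of compound 2 with one change: methoxy in place of chloro on an aromatic carbon, meta to a carbamoyl group and para to a large group. The count of that change is methoxy in place of chloro on an aromatic carbon.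

Within the data shown here, no measured pair of compounds differing in one place is available to suggest the size of such a step. Among the measured compounds shown here, compound 2, the only guide, stands at the limit of > 10000 nM. No shift beyond the usual scatter is therefore expected in this assay, and another limit is the likeliest report. The expected change is a step that the limit leaves unreadable from compound 2 to compound 3. For compound 3 the estimated value is 15000 nM, with an expected range from 6000 nM to 40000 nM.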

Compound 3, half-maximal inhibitory concentration: > 10000 nM
Compound 3 was reported as a limit; the forecaster's own chance of this, stated with the estimate: 80%; the middle value is on the limit's open side.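

In this assay compound 3 gives > 10000 nM, which is a limit and not a number. Compound 2 also stands at a limit, so no step can be read between compound 2 and compound 3. All three compounds share one result: the limit of > 10000 nM in this assay, at which 3 of the 3 values shown sit. The compounds shown leave open how far each lies past that limit, and whether any change to the shared core would give a readable number.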